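Nitro to methoxy on the cyanophenyl ring

The source may hold more compounds than are shown below. What is called first, only, known or untested is meant among the compounds shown, and "the series" means these compounds.

Compound 1, `N#Cc1cc(C#N)cc(-n2nnc(-c3ccccn3)n2)c1`: 18 nM in an assay on cell membranes for binding affinity to metabotropic glutamate receptor 5 (Rattus norvegicus); on this read-out lower numbers stand for stronger inhibition and higher numbers for weaker inhibition
Compound 2, `N#Cc1cc(-n2nnc(-c3ccccn3)n2)cc([N+](=O)[O-])c1`: 42 nM in this assay

Among the compounds with values here, compound 2 stands at the higher of the two numbers in this assay; the single measured step, a 2.3-fold higher number from compound 1 to compound 2 (0.37 log units; beyond the scatter), separates it from compound 1. Compound 3, `COc1cc(C#N)cc(-n2nnc(-c3ccccn3)n2)c1`, has not yet been measured. It arises from compound 2 by methoxy in place of nitro on an aromatic carbon. Within the data shown here, no measured step involves a methoxy group, so the expectation rests only on the one known step, a 2.3-fold higher number from compound 1 to compound 2 (0.37 log units; beyond the scatter), which shows that exchanging one small group for another on this aromatic carbon moved the number modestly. A step of similar, modest size is therefore expected for compound 3 in this assay, most likely towards a higher number, though a step within the scatter cannot be excluded. Compound 3 is estimated at 60 nM, between 20 nM and 180 nM, which means an expected step of a 1.4-fold higher number from compound 2 to compound 3 (0.15 log units; within the scatter).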

Compound 3, inhibition constant: 6 nM
For compound 3 the middle estimate is 10-fold (1.00 log units) above the measured one; the measured number lies below the stated range.
By their numbers in this assay, from the lowest: compound 3; then compound 1; then compound 2.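

In this assay, within the data shown here, this position proves more responsive than the first pair suggested: the step of a 7.0-fold lower number from compound 2 to compound 3 (0.85 log units; beyond the scatter) is larger than the only step known before. The second comparison, a 3.0-fold lower number from compound 1 to compound 3 (0.48 log units; beyond the scatter), shows that methoxy does not merely improve on nitro but also gives a lower number than cyano. Of the three groups seen on this aromatic carbon, methoxy therefore gives the lowest number, whereas the earlier compounds showed only that nitro gave a higher number than cyano, and nothing available here explains this difference between the groups.

From the compounds shown here alone, it remains open whether an ethoxy group, a hydroxyl group, an amine or a fluorine atom on this carbon would give a lower or a higher number. Going by these compounds, it is also open whether methoxy keeps its advantage when the remaining cyano group is exchanged for another group.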